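Replacing a Chain with an Aryl Amide: Cytotoxicity Outlook

The source may hold more compounds than are shown below. What is called first, only, known or untested is meant among the compounds shown, and "the series" means these compounds.

Of the compounds shown here, three have been tested in an ADME assay on HepG2 2.2.15 cells (Homo sapiens) for cytotoxicity; a lower number here means that less compound is tolerated, a higher number that more compound is tolerated. Compound 1 `COCCc1ccc(OC(c2ccc(Cl)cc2)c2cnc(NC(=O)OC(C)(C)C)s2)cc1` reaches only the limit of the assay, > 50000 nM, so no number is known for it. Compound 2 `O=C(Nc1ncc(C(OCc2ccc(F)cc2F)c2ccccc2)s1)c1cccs1` is reported as "not toxic" (no number reported). Compound 3 `COCCCNc1ncc(C(Oc2ccc3cc(Br)ccc3c2)c2ccc(Cl)cc2)s1` is likewise reported as "not toxic" (no number reported), without a single number, so its standing rests on that report alone. Compound 4 `Cc1ccc(C(=O)Nc2ncc(C(Oc3ccc4cc(Br)ccc4c3)c3ccc(Cl)cc3)s2)cc1` differs from compound 3 in one place: (4-methylphenyl)carbonyl in place of 3-methoxypropyl on a nitrogen on an aromatic ring. Among the measured compounds shown here, no step between measured compounds exists to guide the size of this change, and nothing seen so far shows toxicity within the measured range, as in the limit of > 50000 nM in this assay, at which 1 of the 3 values shown sits. Compound 4 is therefore expected, on the strength of the limit of > 50000 nM in this assay, at which 1 of the 3 values shown sits, to sit near 60000 nM, most likely between 20000 nM and 200000 nM.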

Compound 4, half-maximal cytotoxic concentration: "not toxic" (no number reported)
Nothing numeric was reported for compound 4, and the estimate cannot be compared.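

Compound 3 and compound 4 are both reported only as "not toxic", so no step can be read between them. The compounds shown leave open how much of either compound this assay would tolerate, and whether the aryl amide changes that at all.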